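A few compounds are considered here, and "the series" means these few. Any claim that something is new, unique, unknown or untested is made for them only; others in the source may bear on it.

In a functional assay on THP-1 cells (Homo sapiens) for inhibition, read by sulforhodamine B assay, with a stated time of 48 h (on this read-out lower numbers stand for stronger inhibition and higher numbers for weaker inhibition), compound 1 `COC(=O)[C@H]1C[C@@H](c2coc3ccccc3c2=O)N(c2ccccc2)O1` gives > 60000 nM, which is a limit of the assay and not a number. It therefore stands at the limit of > 60000 nM in this assay, at which 1 of the 2 values shown sits. Compound 2 `O=c1c([C@@H]2C[C@H](c3ccncc3)ON2c2ccccc2)coc2ccccc12`, with pyridin-4-yl in place of methoxycarbonyl on a saturated ring carbon, gives 16400 nM. Among the measured compounds shown here, this is the only measured step so far: an at least 3.6-fold lower number from compound 1 to compound 2 (0.56 log units; beyond the scatter).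

Compound 3 `COC(=O)[C@H]1C[C@@H](c2coc3ccc(Cl)cc3c2=O)N(c2ccccc2)O1` keeps the methoxycarbonyl of compound 1 and changes elsewhere, with chloro in place of hydrogen on an aromatic carbon. The step to compound 2 16400 nM was made at a different place, so it offers only weak guidance on this change. It does show that a compound with this core can give a real number in this assay. For the measured compounds named here, no measured compound yet carries chloro, so the size of the new step remains open, and compound 3 may again reach only a limit. A modest move towards a lower number seems the most reasonable expectation. The estimated change is an at least 1.5-fold lower number from compound 1 to compound 3 (0.17 log units; that floor lies within the scatter). For compound 3 the expected value is 40000 nM, within an estimated range from 15000 nM to 100000 nM.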

Compound 3, half-maximal inhibitory concentration: > 60000 nM
Compound 3: a limit, no number (the forecaster's own chance of this, stated with the estimate: 55%); at least 1.5-fold (0.17 log units) between middle value and limit.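

In this assay compound 3 gives > 60000 nM as a limit of the assay and not a number. The step from compound 1 to compound 3 cannot be read, because both compounds stand at the same limit: the limit of > 60000 nM in this assay, at which 2 of the 3 values shown sit. From the compounds shown here alone, how far chloro in place of hydrogen moves the number on the shared core stays open.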